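Morpholine in Place of Hydroxyethylamine on the Longer Chain

The source may report more compounds than this note shows. Statements on the series, on what has been measured and on what is new or still open speak of the compounds shown alone.

Measured compounds in a functional assay on a cell-free system (plasma, Oryctolagus cuniculus) for inhibition of platelet-activating factor acetylhydrolase (Homo sapiens), tested at 100 nM; a lower number here means less inhibition, a higher number more inhibition at the concentration tested (going by the name of the read-out):
Compound 1 `CCCCCCCCN(C)C(=O)Cn1cc(Cc2cnc(=O)n(CC(=O)NCCO)c2)c(=O)nc1SCc1ccc(F)cc1` gives 40%.
Compound 2 `CCCCCCCCN(C)C(=O)Cn1cc(Cc2cnc(=O)n(CC(=O)N3CCOCC3)c2)c(=O)nc1SCc1ccc(F)cc1` gives 36%.
Compound 3 `CCCCCCCCCCCCN(C)C(=O)Cn1cc(Cc2cnc(=O)n(CC(=O)NCCO)c2)c(=O)nc1SCc1ccc(F)cc1` gives 37%.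

Among the measured compounds shown here, all three values sit close together, and no step among them goes beyond the scatter. From compound 1 to compound 2 the change is morpholin-4-yl in place of (2-hydroxyethyl)amino on a carbonyl carbon; in this assay this gave a number 4 percentage points lower from compound 1 to compound 2 (within the scatter). Compound 3 differs from compound 1 in its core: butyl in place of hydrogen on a saturated chain carbon, eight bonds along the chain from an amide-type nitrogen; in this assay that step was a number 3 percentage points lower from compound 1 to compound 3 (within the scatter). Compound 4 `CCCCCCCCCCCCN(C)C(=O)Cn1cc(Cc2cnc(=O)n(CC(=O)N3CCOCC3)c2)c(=O)nc1SCc1ccc(F)cc1` has not been measured. It differs from compound 3 by morpholin-4-yl in place of (2-hydroxyethyl)amino on a carbonyl carbon, the same change as from compound 1 to compound 2, made at the same place but on the core that carries the longer chain. Because the earlier instance gave a number 4 percentage points lower from compound 1 to compound 2 (within the scatter), the step for compound 4 is expected to be about a number 4 percentage points lower from compound 3 to compound 4 (within the scatter) in this assay. Compound 4 is therefore estimated at 33% in this assay, with a likely range from 22% to 44%.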

Compound 4, a percentage reported as inhibition, at one concentration (the size of the read-out at that concentration, not a potency): 30%
Estimate against measurement, compound 4: 3 percentage points above; measured number inside the range.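

In this assay, morpholin-4-yl in place of (2-hydroxyethyl)amino on the core with the longer chain gave a number 7 percentage points lower from compound 3 to compound 4 (within the scatter), and this step matches the earlier one on the shorter chain: the same change on two cores in this assay, a number 4 percentage points lower (within the scatter) from compound 1 to compound 2 and a number 7 percentage points lower (within the scatter) from compound 3 to compound 4, 3 percentage points apart, within the scatter of two such steps. Adding butyl to the chain, now with morpholin-4-yl in place, gave a number 6 percentage points lower from compound 2 to compound 4 (within the scatter), and this also matches its earlier counterpart: the same change on two cores in this assay, a number 3 percentage points lower (within the scatter) from compound 1 to compound 3 and a number 6 percentage points lower (within the scatter) from compound 2 to compound 4, 3 percentage points apart, within the scatter of two such steps. Each change therefore carried from one core to the other with no difference that can be read, but all of these steps lie within the scatter, so this does not show that either change has a real effect, and two cores say nothing about other cores.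

The compounds shown leave open whether a different group on the carbonyl carbon, such as a simple amine or a piperazine, would move the number beyond the scatter. They also leave open how a shorter chain would behave, and how these compounds compare in potency, since each number is a reading at a single concentration.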